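Chain shortening on an acylated core: estimate for compound 4

This account rests on a few compounds, and the source may have more. Where it says the series, first, only, none or still open, it means among the compounds named here.

Measured so far, in a functional assay on HeLa cells (Homo sapiens) for cytotoxicity, read by MTT assay, with a stated time of 24 h; on this read-out lower numbers stand for stronger inhibition and higher numbers for weaker inhibition:
compound 1, `CCCCCC(=O)Nc1nnc(S[C@@H]2O[C@H](CO)[C@H](O)[C@H](O)[C@H]2O)s1`, gives 45600 nM;
compound 2, `CCCCCCCCCCCCCC(=O)Nc1nnc(S[C@@H]2O[C@H](CO)[C@H](O)[C@H](O)[C@H]2O)s1`, gives 31000 nM;
compound 3, `CCCCCCCCCCCCCCCC(=O)Nc1nnc(S[C@@H]2O[C@H](COC(C)=O)[C@H](OC(C)=O)[C@H](OC(C)=O)[C@H]2OC(C)=O)s1`, gives 58300 nM.

Compound 1 and compound 2 share a core and differ by hydrogen in place of octyl on a saturated chain carbon, five bonds along the chain from a carbonyl carbon. That change produced a 1.5-fold higher number from compound 2 to compound 1 (0.17 log units; within the scatter), so the two numbers lie within the scatter of one another and carry no order between them. Compound 3 stands on a different core; the difference between the cores of compound 3 and compound 2 is not broken down here, and the values of the two simply sit within the scatter of each other.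

Compound 4, `CCCCCCCC(=O)Nc1nnc(S[C@@H]2O[C@H](COC(C)=O)[C@H](OC(C)=O)[C@H](OC(C)=O)[C@H]2OC(C)=O)s1`, has not yet been measured. It differs from compound 3 by hydrogen in place of octyl on a saturated chain carbon, seven bonds along the chain from a carbonyl carbon. Within the data shown here, this is the same kind of change as the one from compound 2 to compound 1, but the place is not identical: there the hydrogen entered five bonds along the chain from a carbonyl carbon, here it enters seven bonds along the chain from a carbonyl carbon.

Among the measured compounds shown here, for compound 4 in this assay the expected step is a 1.2-fold higher number from compound 3 to compound 4 (0.08 log units; within the scatter), resting on the single earlier instance of this kind of change, a 1.5-fold higher number from compound 2 to compound 1 (0.17 log units; within the scatter), which stayed within the scatter. On that basis compound 4 is estimated at 70000 nM, with the expected range running from 30000 nM to 160000 nM.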

Compound 4, half-maximal inhibitory concentration: 43600 nM
For compound 4 the middle estimate is 1.6-fold (0.21 log units) above the measured one; the range from low to high includes it.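

In this assay, hydrogen in place of octyl on a saturated chain carbon, seven bonds along the chain from a carbonyl carbon, gives a 1.3-fold lower number from compound 3 to compound 4 (0.13 log units; within the scatter), so these two numbers carry no order between them. Set beside the earlier instance of this kind of change, the step on the second core cannot be told apart from the step on the first: the same change on two cores in this assay, a 1.5-fold higher number (0.17 log units; within the scatter) from compound 2 to compound 1 and a 1.3-fold lower number (0.13 log units; within the scatter) from compound 3 to compound 4, 2.0-fold (0.29 log units) apart, within the scatter of two such steps. Among these compounds, this shows only that the change stayed within the scatter on both cores; it does not show that the chain has any bearing on the read-out on either core, and two pairs, with the change at five bonds along the chain in one and seven in the other, establish no rule for carrying it to a further core.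

Among the compounds shown, the two cores never carry the same chain, so the difference between the cores alone stays unread. Also open, going by these compounds, is whether a longer chain, or an amine or a carboxylic acid at the far end of the chain, would give a step beyond the scatter in this assay.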